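The source may hold more compounds than are shown below. What is called first, only, known or untested is meant among the compounds shown, and "the series" means these compounds.

Among the measured compounds shown here, compound 3, `COc1cc(C(c2ccc(O)c(OC)c2)[C@H](CC(C)C)C(C)C)ccc1O`, gives 9600 nM in a functional assay on HL-60 cells (Homo sapiens) for cytotoxicity, read by WST assay, with a stated time of 48 h (a lower number here means a stronger inhibitor, a higher number a weaker inhibitor), and so stands at the lowest of the three numbers so far. Compound 1, `COc1cc(C(c2ccc(O)c(OC)c2)[C@H](C)[C@H](C)CF)ccc1O`, gives 56000 nM, and compound 2, `COc1cc(C(c2ccc(O)c(OC)c2)[C@H](C)[C@@H](C)CF)ccc1O`, gives 45000 nM. The step of a 1.2-fold lower number from compound 1 to compound 2 (0.09 log units; within the scatter) rests on (the fact that compounds 1 and 2 differ only in the configuration as drawn), while the steps of a 5.8-fold lower number from compound 1 to compound 3 (0.77 log units; beyond the scatter) and a 4.7-fold lower number from compound 2 to compound 3 (0.67 log units; beyond the scatter) show that the larger branched alkyl chain went with a lower number in both cases.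

Compound 4, `CC[C@H](C(C)C)C(c1ccc(O)c(OC)c1)c1ccc(O)c(OC)c1`, is not yet measured. It differs from compound 3 by methyl in place of isopropyl on a saturated chain carbon, three bonds along the chain from two aromatic carbons, which leaves the core and both aromatic parts untouched and trims the branched chain. For the measured compounds named here, no measured step matches this change exactly; the closest evidence is the pair of modest steps to compound 3, where a bulkier chain lowered the number, and the change here goes the opposite way, removing carbon from that chain. A modest rise beyond the scatter is therefore expected, smaller than those steps since the chain of compound 4 still carries branching.

For compound 4 the estimated value in this assay is 20000 nM, with a range from 8000 nM to 50000 nM, which corresponds to an expected step of a 2.1-fold higher number from compound 3 to compound 4 (0.32 log units; beyond the scatter).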

Compound 4, half-maximal inhibitory concentration: 16000 nM
For compound 4 the middle estimate is 1.3-fold (0.10 log units) above the measured one; the range from low to high includes it.
By their numbers in this assay, from the lowest: compounds 3 and 4 (each within the scatter of the next); then compounds 2 and 1 (each within the scatter of the next).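

In this assay, swapping isopropyl for methyl on a saturated chain carbon, three bonds along the chain from two aromatic carbons, gives a step that does not rise above the usual scatter: a 1.7-fold higher number from compound 3 to compound 4 (0.22 log units; within the scatter). So this position tolerates the shorter 1-isopropylpropyl chain in place of 1-isopropyl-3-methylbutyl, and the lower numbers do not depend on the larger chain, since the 1-isopropylpropyl chain still goes with a lower number than 2-(fluoromethyl)-1-methylpropyl, with a 2.8-fold lower number from compound 2 to compound 4 (0.45 log units; beyond the scatter) and with a 3.5-fold lower number from compound 1 to compound 4 (0.54 log units; beyond the scatter). Nothing in the available evidence accounts for the size of these steps.

The two chains compared in those last steps differ in the fluoromethyl group as well as in their branching, so the compounds shown do not separate the part played by the fluorine from that of the chain's shape, and a plain isobutyl or sec-butyl chain on the same carbon would be needed to tell them apart. From the compounds shown here alone, what a longer chain such as n-hexyl, or a chain ending in an amine or a carboxylic acid, would do at this position also stays open.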